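This account rests on a few compounds, and the source may have more. Where it says the series, first, only, none or still open, it means among the compounds named here.

Measured so far:
Compound 1, `O=C(COc1cccc2ccccc12)N/N=C/C=C/c1ccccc1` — in an ADME assay on HEL cells (Homo sapiens) for cytotoxicity (a higher number here means that more compound is tolerated, a lower number that less compound is tolerated), compound 1 gives 100 ug/mL.
Compound 2, `O=C(COc1cccc2ccccc12)N/N=C/c1ccccc1` — in this assay compound 2 gives 100 ug/mL.

Among the compounds with values here, the one measured step runs from compound 1 to compound 2, phenyl in place of 2-phenylethenyl on a carbon with a double bond to nitrogen, and it reads no change at the digits printed from compound 1 to compound 2 (within the scatter). Compound 2 therefore stands level with compound 1 on the numbers shown, with nothing to separate the two beyond the scatter.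

Compound 3, `Cc1ccc(/C=N/NC(=O)COc2cccc3ccccc23)cc1`, is not yet measured. It differs from compound 2 by methyl in place of hydrogen on an aromatic carbon. Within the data shown here, no measured step bears directly on this change; the only comparison available, from compound 1 to compound 2, showed no movement even with a larger alteration at the same end of the molecule. The step from compound 2 to compound 3 is thus expected to be no change at the digits printed from compound 2 to compound 3 (within the scatter). For compound 3 the estimated value in this assay is 100 ug/mL, with a range from 50 ug/mL to 200 ug/mL.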

Compound 3, minimum cytotoxic concentration: 20 ug/mL
Estimate against measurement, compound 3: 5.0-fold (0.70 log units) above, and the stated range ends above it.
By their numbers in this assay, from the lowest: compound 3; then compounds 1 and 2 (each within the scatter of the next).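

The position para to a large group, on the six-membered aromatic ring of carbon only, proves sensitive in this assay: methyl in place of hydrogen gives a clear shift (a 5.0-fold lower number from compound 2 to compound 3 (0.70 log units; beyond the scatter)), whereas replacing 2-phenylethenyl with phenyl at that end of the molecule had left the number unmoved (no change at the digits printed from compound 1 to compound 2 (within the scatter)). One added carbon is therefore enough to separate compound 3 from both earlier compounds, and the 4-methylphenyl group in place of 2-phenylethenyl shows the same gap (a 5.0-fold lower number from compound 1 to compound 3 (0.70 log units; beyond the scatter)). No supporting evidence is available to explain this shift.

Going by these compounds, whether the drop is particular to methyl or would also follow an ethyl group, a methoxy group, a chlorine atom or an amine at this position remains open. Also open, on these data alone, is whether the same methyl would lower the number on the 2-phenylethenyl end of compound 1.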